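Chloro for tert-Butyl: Expected Solubility of Compound 4

The compounds below may be only part of what the source reports. "The series", "measured", "known", "first", "only" and "open" are said of these compounds alone.

Among the measured compounds shown here, compound 1 `CC(C)(C)c1ccc(Oc2ccc3c(NCCCNCc4ccco4)ccnc3c2)cc1` is one of three compounds measured in a physicochemical assay for solubility, with a stated time of 18 h, at pH 7.4; on this read-out higher numbers stand for higher solubility and lower numbers for lower solubility. In this assay compound 1 gives 14500 nM. Compound 2 `COc1ccc(Oc2ccc3c(NCCCNCc4cc(F)ccc4OC)ccnc3c2)cc1` gives 14500 nM, level with compound 1 at the digits shown, and the two together hold the highest of the three numbers. Compound 3 `COc1ccc(F)cc1CNCCCNc1ccnc2cc(Cc3ccc(F)cc3Cl)ccc12` gives 4200 nM, the lowest of the set. For the measured compounds named here, the only single-point step among the measured compounds is a 3.5-fold lower number from compound 2 to compound 3 (0.54 log units; beyond the scatter), a change of the group on the aromatic carbon that is unrelated to the one considered here.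

Compound 4 `Clc1ccc(Oc2ccc3c(NCCCNCc4ccco4)ccnc3c2)cc1` differs from compound 1 in one place: chloro in place of tert-butyl on an aromatic carbon. Going by the values given here, no measured step covers this exchange, so the step from compound 2 to compound 3 gives only a sense of scale, not direction. With nothing in the data pointing either way, the expected step of a 1.0-fold lower number from compound 1 to compound 4 (0.02 log units; within the scatter) is small, within the scatter or at most modest. Compound 4 is therefore estimated at 14000 nM, with a range from 6000 nM to 32000 nM.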

Compound 4, solubility: 14500 nM
Beside the measured number, compound 4's estimate is 1.0-fold (0.02 log units) below it; the measured number falls inside the stated range.
By their numbers in this assay, from the lowest: compound 3; then compounds 1, 2 and 4 (each within the scatter of the next).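

In this assay chloro in place of tert-butyl gives no change at the digits printed from compound 1 to compound 4 (within the scatter), so on this six-membered aromatic ring of carbon only, the read-out does not respond to an exchange that swaps four carbon atoms for one chlorine. Among the compounds shown here, the one earlier step replaced the whole 4-methoxyphenoxy group with 2-chloro-4-fluorobenzyl and said nothing about an exchange at this place alone. No measurement at hand offers an explanation for this result.

Both groups compared here carry no charge and no hydrogen-bond donors or acceptors, so the compounds shown leave open whether a group with such features, an amine or a carboxylic acid, would also leave the number unchanged at this place. They also leave open whether chloro and tert-butyl would match on a compound with a different side chain.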